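A few compounds are considered here, and "the series" means these few. Any claim that something is new, unique, unknown or untested is made for them only; others in the source may bear on it.

Of the compounds shown here, three have been measured in a functional assay, with a stated time of 20 min, tested at 10 uM; a lower number here means a weaker effect, a higher number a stronger effect of the compound at the concentration tested. Compound 1, `COc1cc(/C=C/C(=O)C2=C(/C=C/c3ccc(O)c(OC)c3)NC(=O)NC2c2c(Cl)cccc2Cl)ccc1O`, gives 19.2% in this assay. Compound 2, `COc1cc(/C=C/C(=O)C2=C(/C=C/c3ccc(O)c(OC)c3)NC(=O)NC2c2ccccc2Cl)ccc1O`, differs from compound 1 in one place: hydrogen in place of chloro on an aromatic carbon. In this assay compound 2 gives 40%, so this change made a step of a number 20.8 percentage points higher from compound 1 to compound 2 (beyond the scatter). Compound 3, `COc1cc(/C=C/C(=O)C2=C(/C=C/c3ccc(O)c(OC)c3)NC(=S)NC2c2c(Cl)cccc2Cl)ccc1O`, shares much with compound 1, but the difference between the two cores is not broken down here. In this assay compound 3 gives 29%; its value and that of compound 1 lie within the scatter of each other.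

Compound 4, `COc1cc(/C=C/C(=O)C2=C(/C=C/c3ccc(O)c(OC)c3)NC(=S)NC2c2ccccc2Cl)ccc1O`, has not yet been measured. It differs from compound 3 in one place: hydrogen in place of chloro on an aromatic carbon. Within the data shown here, this is the same change as the one from compound 1 to compound 2, made at the same place, now on the core of compound 3. Among the measured compounds shown here, only one earlier instance of this change exists, so any expectation rests on that single step. The expected step in this assay is a number 21 percentage points higher from compound 3 to compound 4 (beyond the scatter), resting on the earlier step of a number 20.8 percentage points higher from compound 1 to compound 2 (beyond the scatter). Compound 4 is therefore estimated to give 50%, with a likely range from 35% to 65%.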

Compound 4, a percentage reported as activity, at one concentration (the size of the read-out at that concentration, not a potency): 43.2%
The estimate for compound 4 lay 6.8 percentage points above the measured number, within the range that was stated.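

The same change, 2,6-dichlorophenyl to 2-chlorophenyl, made on a second core gave in this assay a number 14.2 percentage points higher from compound 3 to compound 4 (beyond the scatter), the same direction as on the core of compound 1. Set side by side, the two steps do not differ by more than repeated measurements of this kind would: the same change on two cores in this assay, a number 20.8 percentage points higher (beyond the scatter) from compound 1 to compound 2 and a number 14.2 percentage points higher (beyond the scatter) from compound 3 to compound 4, 6.6 percentage points apart, within the scatter of two such steps On these two cores, then, removing this chloro group carried over in direction and, within the scatter, in size, but two pairs are a small base: they do not show that it would hold on any further core, and they do not explain why the number rises.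

As far as these compounds go, what a fluoro, methyl or methoxy group would do in place of the remaining chloro stays open, as does whether a phenyl ring with no chloro at all would continue the rise. Each number is also a read-out at one concentration, so whether the effect of these compounds would be stronger or weaker at other concentrations remains open too.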